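This account rests on a few compounds, and the source may have more. Where it says the series, first, only, none or still open, it means among the compounds named here.

In a functional assay on HCT-116 cells (Homo sapiens) for inhibition, read by MTT assay, with a stated time of 48 h, tested at 2 uM (on this read-out lower numbers stand for less inhibition and higher numbers for more inhibition at the one concentration tested (going by the name of the read-out)), compound 1 `Cc1noc(C)c1-c1ccc2c(c1)C(c1ccccc1)NC(=O)N2C` gives 27.8%, compound 2 `Cc1noc(C)c1-c1ccc2c(c1)C(c1ccccc1)N(Cc1nc(-c3ccccc3)cs1)C(=O)N2C` gives 26.7%, and compound 3 `Cc1nc(-c2ccc(F)cc2)sc1CN1C(=O)N(C)c2ccc(-c3c(C)noc3C)cc2C1c1ccccc1` gives 26%. All three numbers lie within the usual scatter of one another, so compound 2 stands level with the other two rather than apart from them. Compound 4 `Cc1noc(C)c1-c1ccc2c(c1)C(c1ccccc1)N(Cc1nnc(-c3ccc(F)cc3)o1)C(=O)N2C` has not yet been tested. It differs from compound 2 by 5-(4-fluorophenyl)-1,3,4-oxadiazol-2-yl in place of 4-phenyl-1,3-thiazol-2-yl on a saturated chain carbon bound to an amide-type nitrogen in a ring. For the measured compounds named here, the one measured step that bears on this is a number 1.1 percentage points lower from compound 1 to compound 2 (within the scatter): attaching the whole group on the amide-type nitrogen in a ring changed nothing beyond the scatter, and compound 3, carrying a related group there, gives a number in the same band. The expected step of a number 0.7 percentage points lower from compound 2 to compound 4 (within the scatter) is therefore none beyond the scatter. Compound 4 is expected to give 26%, between 14% and 38%.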

Compound 4, a percentage reported as inhibition, at one concentration (the size of the read-out at that concentration, not a potency): 36.6%
Compound 4: middle estimate off by 10.6 percentage points, on the low side; the measured number falls inside the stated range.
By their numbers in this assay, from the lowest: compounds 3, 2, 1 and 4 (each within the scatter of the next, the first and the last beyond it).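

In this assay, 5-(4-fluorophenyl)-1,3,4-oxadiazol-2-yl in place of 4-phenyl-1,3-thiazol-2-yl gives a number 9.9 percentage points higher from compound 2 to compound 4 (within the scatter), so this place on the saturated chain carbon accepts a five-membered aromatic ring other than a thiazole with no change beyond the scatter. No measurement shown offers a reason for this step. The swap replaces the five-membered ring and brings in a fluorine at the same time, so the compounds shown cannot separate these two changes. From the compounds shown here alone, how an amine or a carboxylic acid in this place would read also remains open.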